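Ethyl on a ring nitrogen of compound 2

A few compounds are considered here, and "the series" means these few. Any claim that something is new, unique, unknown or untested is made for them only; others in the source may bear on it.

In an ADME assay on HMEC cells (Homo sapiens) for antiproliferative activity, read by MTT assay (a lower number here means a stronger inhibitor, a higher number a weaker inhibitor), compound 1 `Nc1ccccc1NC(=O)c1ccc(CN2Cc3ccccc3C2=O)cc1` gives 37000 nM and compound 2 `Nc1ccccc1NC(=O)c1ccc(Cn2c(=O)[nH]c3ccsc3c2=O)cc1` gives 29000 nM and these two values lie within the usual scatter of each other. Compound 3 `CCn1c(=O)n(Cc2ccc(C(=O)Nc3ccccc3N)cc2)c(=O)c2sccc21` differs from compound 2 by a single change: ethyl in place of hydrogen on an aromatic nitrogen. Among the measured compounds shown here, no measured step yet shows what such a change does, so only a small shift is expected in this assay and none beyond the scatter (estimated step a 1.2-fold lower number from compound 2 to compound 3 (0.06 log units; within the scatter)). For compound 3 the expected value is 25000 nM (estimated range 10000 nM to 60000 nM).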

Compound 3, half-maximal inhibitory concentration: > 50000 nM
Compound 3: no number, only a limit (the forecaster's own chance of this, stated with the estimate: 15%); middle value at least 2.0-fold (0.30 log units) from the limit.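

Ethyl in place of hydrogen on this aromatic nitrogen now has its first measured step in this assay (an at least 1.7-fold higher number from compound 2 to compound 3 (0.23 log units; that floor lies within the scatter)). Compound 3 gives > 50000 nM as a limit and not a number. The change brought no gain in this assay, and its step is only a floor because the reading stops at a limit: the limit of > 50000 nM in this assay, at which 1 of the 3 values shown sits.

From the compounds shown here alone, how far compound 3 truly lies from compound 2 stays unknown. Also open, going by these compounds, is how a methyl, a longer chain such as propyl, or an amine would behave on this nitrogen.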